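This account rests on a few compounds, and the source may have more. Where it says the series, first, only, none or still open, it means among the compounds named here.

Compound 1 `CC1(COC(=O)N2CC3COCC(C2)C3Oc2ncnc(Nc3ccc(C#N)cc3Cl)c2F)COC1` stands lowest of the three compounds measured in a functional assay for agonist activity at Glucose-dependent insulinotropic receptor (Mus musculus), read by cAMP accumulation (a higher number here means a larger maximal response, a lower number a smaller maximal response), where compound 1 gives 46%. Compound 2 `CC1(OC(=O)N2C[C@H]3COC[C@@H](C2)[C@@H]3Oc2ncnc(Nc3ccccc3F)c2F)CC1` gives 76%, and compound 3 `CC1(OC(=O)N2C[C@H]3COC[C@@H](C2)[C@@H]3Oc2ncnc(Nc3c(F)cccc3F)c2F)CC1` gives 108%. Within the data shown here, the only step between neighbours that differ in one place is a number 32 percentage points higher from compound 2 to compound 3 (beyond the scatter), and it concerns fluoro in place of hydrogen on an aromatic carbon, a part of the molecule that is untouched in the step followed here.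

Compound 4 `N#Cc1ccc(Nc2ncnc(OC3C4COCC3CN(C(=O)OC3CCC3)C4)c2F)c(Cl)c1` differs from compound 1 by cyclobutyl in place of (3-methyloxetan-3-yl)methyl on an oxygen next to a carbonyl group. Among the measured compounds shown here, no two measured compounds differ in this part of the structure, so the change has no precedent among them, and the step from compound 2 to compound 3 does not bear on it. With nothing to suggest a shift in either direction, the step of no change at the digits printed from compound 1 to compound 4 (within the scatter) is expected to stay within the scatter. The estimate for compound 4 in this assay is 46%, with a range from 25% to 70%.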

Compound 4, largest response reached (reported as percent of maximum), in percent of the reference or control that the assay uses: 60%
Compound 4: the middle estimate sits 14 percentage points below what was measured; the range from low to high includes it.
By their numbers in this assay, from the lowest: compound 1; then compound 4; then compound 2; then compound 3.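

In this assay, the group on an oxygen next to a carbonyl group proves able to move the maximal response: cyclobutyl in place of (3-methyloxetan-3-yl)methyl gives a number 14 percentage points higher from compound 1 to compound 4 (beyond the scatter) and a step beyond the scatter. Among these compounds, this is the first measured change at this position, and it shows that the carbocyclic group with fewer heavy atoms is tolerated on the core of compound 1 without loss of response. No supporting measurement accounts for this step.

Among the compounds shown here, the single exchange alters the heavy-atom count and removes the ring hetero atom together, so the contribution of each remains unresolved. As far as these compounds go, it also remains open how an oxetan-3-yl group, with its ring oxygen but no methyl or methylene, or an azetidine ring on the same oxygen would compare with cyclobutyl.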